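The compounds below may be only part of what the source reports. "The series", "measured", "known", "first", "only" and "open" are said of these compounds alone.

Series notes. In an assay on HEK293 cells for agonist activity at transient receptor potential cation channel subfamily M member 8 (Homo sapiens), read by fluorescence and calcium flux, with a stated time of 15 min (on this read-out lower numbers stand for an effect already at smaller amounts and higher numbers for an effect only at larger amounts of compound), compound 1 `CCN(Cc1cccs1)C(=O)c1cc2cc(C)ccc2o1` gives 120 nM, compound 3 `CCN(Cc1cccs1)C(=O)COc1ccc(C)cc1O` gives 8 nM, and compound 2 `Cc1ccc(OCC(=O)N(Cc2cccs2)c2ncccn2)cc1` gives 3700 nM. Compound 2 thus carries the highest number of the three: compound 1 stands nearest to it, compound 3 furthest, both gaps beyond the scatter. Compound 4 `Cc1ccc(OCC(=O)N(Cc2cccs2)c2ccccc2)cc1` has not been measured in this assay; compared with compound 2 the change is phenyl in place of pyrimidin-2-yl on an amide-type nitrogen. Among the compounds with values here, no measured pair shows this change, so the size of the step rests on no precedent. The expectation is a modest step from compound 2 to compound 4 toward a lower number, a 2.1-fold lower number from compound 2 to compound 4 (0.31 log units; beyond the scatter), of a size near the edge of the scatter. Compound 4 is accordingly estimated at 1800 nM, with a range from 400 nM to 8000 nM.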

Compound 4, half-maximal effective concentration: 23 nM
The estimate for compound 4 lay 78-fold (1.89 log units) above the measured number, outside the stated range (below it).
By their numbers in this assay, from the lowest: compound 3; then compound 4; then compound 1; then compound 2.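

In this assay, phenyl in place of pyrimidin-2-yl on an amide-type nitrogen gives a 160-fold lower number from compound 2 to compound 4 (2.21 log units; beyond the scatter), a large step beyond the scatter. With the heavy-atom count unchanged, a six-membered aromatic ring of carbon only replaces one with 2 hetero atoms, so the number at this position depends strongly on which ring the nitrogen carries. Nothing available accounts for the size of this step. Open, going by these compounds, is whether pyridin-2-yl, with a single ring nitrogen, stands nearer compound 2 or compound 4. Also open, on these data alone, is whether cyclohexyl or fluorophenyl on this nitrogen keeps the number of compound 4.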